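Fluorine Where Chlorine Once Sat: Compound 4

The compounds below may be only part of what the source reports. "The series", "measured", "known", "first", "only" and "open" are said of these compounds alone.

Compound 1 `COc1cc(N)c(Cl)cc1NC(=O)C1CCN(Cc2ccccc2Cl)CC1` gives in a functional assay on the whole organism for antagonist activity, with Mus musculus as the target (a higher number here means that more compound is needed for the effect, a lower number that less compound is needed), only a limit of the assay, > 4 mg/kg.
Compound 2 `COc1cc(N)c(Cl)cc1NC(=O)C1CCN(CC2CCCCCC2)CC1` likewise gives only a limit, > 10 mg/kg.
Compound 3 `COc1cc(N)c(Cl)cc1NC(=O)C1CCN(Cc2ccccc2)CC1` gives 0.5 mg/kg.

Compound 3 is thus the only one of the three with a number; the other two stand at limits. Compound 4 `COc1cc(N)c(Cl)cc1NC(=O)C1CCN(Cc2ccccc2F)CC1` differs from compound 3 in one place: fluoro in place of hydrogen on an aromatic carbon.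

Within the data shown here, the step that bears most directly on this is the one between compound 1 and compound 3, where the same aromatic carbon carried chloro instead of hydrogen: an at least 8.0-fold lower number from compound 1 to compound 3 (0.90 log units; beyond the scatter). Its size is readable only as a bound because compound 1 sits at the limit of > 4 mg/kg in this assay, at which 1 of the 3 values shown sits. Read in the reverse direction, putting a halogen onto that carbon raised the number by at least that much. The step of an at least 20-fold lower number from compound 2 to compound 3 (1.30 log units; beyond the scatter) concerns a different part of the molecule and says nothing about this position.

Fluoro is a halogen entering the place chloro occupied in compound 1, so the number for compound 4 is expected to rise, though whether by as much as chloro did cannot be told from these data. The expected step is a 3.0-fold higher number from compound 3 to compound 4 (0.48 log units; beyond the scatter), and the estimate for compound 4 is 1.5 mg/kg, between 0.5 mg/kg and 5 mg/kg.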

Compound 4, dose for half-maximal effect: > 4 mg/kg
Compound 4 gave a limit, no number; the forecaster's own chance of this, stated with the estimate: 20%; at least 2.6-fold (0.42 log units) between middle value and limit.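

Compound 4 shows that chloro was not a special case at this aromatic carbon: a single fluorine atom, in the change from benzyl to 2-fluorobenzyl, already gives an at least 8.0-fold higher number from compound 3 to compound 4 (0.90 log units; beyond the scatter) in this assay. Before this result, only chloro had been seen on this carbon, so the loss could have belonged to that one halogen; now both halogens, ortho to a large group, point the same way, and of the benzyl compounds shown only the one with hydrogen there, compound 3, gives a number. The steps from compound 1 and from compound 2 to compound 4 cannot be read, so fluoro and chloro cannot be ranked against each other, since compound 1 and compound 4 stand at one shared limit: the limit of > 4 mg/kg in this assay, at which 2 of the 4 values shown sit.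

On these data alone, how far the true number of compound 4 lies beyond its limit remains open, and with it whether fluoro costs less than chloro or just as much. Also open, as far as these compounds go, is whether a methyl or a methoxy group on this same carbon would raise the number as well, and whether fluoro on another carbon of the ring would do so.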